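GPR27 agonist series: sulfonamide-linked benzanilides

The source may hold more compounds than are shown below. What is called first, only, known or untested is meant among the compounds shown, and "the series" means these compounds.

Measured so far:
- compound 1 `O=C(Nc1ccc(Cl)cc1Cl)c1ccc(S(=O)(=O)Nc2ccccc2)cc1`: > 100000 nM
- compound 2 `O=C(Nc1cccc(S(=O)(=O)Nc2ccccc2)c1)c1ccc(Cl)cc1Cl`: > 100000 nM
- compound 3 `O=C(Nc1ccc(S(=O)(=O)Nc2ccccc2)cc1)c1ccc(Cl)cc1Br`: 1020 nM

In a functional assay on HEK293 cells for agonist activity at probable G-protein coupled receptor 27 (Homo sapiens), read by a luciferase reporter and beta-arrestin recruitment, with a stated time of 10 min (a higher number here means that more compound is needed for the effect, a lower number that less compound is needed), compound 1 gives > 100000 nM, which is a limit of the assay and not a number. Compound 2 likewise gives only a limit, > 100000 nM. Among the measured compounds shown here, compound 3 is the only member with a measured number, 1020 nM, standing apart from the limit of > 100000 nM in this assay, at which 2 of the 3 values shown sit.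

Compound 4 `Cc1cc(Br)ccc1C(=O)Nc1ccc(S(=O)(=O)Nc2ccccc2)cc1` is not yet measured. It differs from compound 3 by 4-bromo-2-methylphenyl in place of 2-bromo-4-chlorophenyl on a carbonyl carbon. The step from compound 3 to compound 4 is expected to be modest, most likely a small loss of potency or none beyond the scatter, a 2.0-fold higher number from compound 3 to compound 4 (0.29 log units; within the scatter). Compound 4 is estimated at 2000 nM, within 500 nM to 10000 nM.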

Compound 4, half-maximal effective concentration: 851 nM
Estimate against measurement, compound 4: 2.4-fold (0.37 log units) above, and the stated range covers the measured number.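

With 4-bromo-2-methylphenyl in place of 2-bromo-4-chlorophenyl on a carbonyl carbon, the step is a 1.2-fold lower number from compound 3 to compound 4 (0.08 log units; within the scatter), so this position accepts the loss of chlorine and the entry of a methyl group without a readable difference. Measurable activity therefore does not depend on the exact 2-bromo-4-chlorophenyl group, and compound 4 gives a second measured number apart from the assay limit: the limit of > 100000 nM in this assay, at which 2 of the 4 values shown sit.

As far as these compounds go, whether a carboxylic acid or an amine on this phenyl ring would keep a measured number stays open. So does any change to the shared core.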